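Carboxy on the ethyl chain of compound 3

A few compounds are considered here, and "the series" means these few. Any claim that something is new, unique, unknown or untested is made for them only; others in the source may bear on it.

In a functional assay on KB cells (Homo sapiens) for inhibition, with a stated time of 72 h (on this read-out higher numbers stand for weaker inhibition and lower numbers for stronger inhibition), compound 3 `CCn1ccc2cc(C(=O)c3cc(OC)c(OC)c(OC)c3)ccc21` gives 36 nM, the lowest of the numbers in hand. The nearest number belongs to compound 2 `COc1cc(C(=O)c2ccc3cc[nH]c3c2)cc(OC)c1OC`, which gives 510 nM, higher than that of compound 3 and beyond the scatter. Compound 1 `COc1cc(C(=O)n2ccc3ccccc32)cc(OC)c1OC` reads > 10000 nM, which is a limit and not a number.

Compound 4 `COc1cc(C(=O)c2ccc3c(ccn3CCC(=O)O)c2)cc(OC)c1OC` keeps the core of compound 3 and carries carboxy in place of hydrogen on a saturated chain carbon, two bonds along the chain from an aromatic nitrogen. This is ethyl to 2-carboxyethyl. Among the compounds with values here, no measured compound carries carboxy, so the series offers no direct precedent for the change. Within the data shown here, with compound 3 at 36 nM, the lowest number so far, a move in this assay toward a higher number, meaning weaker inhibition, is expected, and it is expected to lie beyond the scatter. The expected step is a 33-fold higher number from compound 3 to compound 4 (1.52 log units; beyond the scatter). For compound 4 the estimated value is 1200 nM, with an expected range of 150 nM to 10000 nM.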

Compound 4, half-maximal inhibitory concentration: > 10000 nM
Compound 4 ended at the assay's limit (the forecaster's own chance of this, stated with the estimate: 20%); middle value at least 8.3-fold (0.92 log units) from the limit.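

This position on the ethyl chain is not open to every change: in this assay, carboxy in place of hydrogen on a saturated chain carbon, two bonds along the chain from an aromatic nitrogen, gives an at least 270-fold higher number from compound 3 to compound 4 (2.44 log units; beyond the scatter). Compound 4 reads > 10000 nM, which is a limit and not a number. The step therefore has a floor but no upper bound, and its true size stays unknown: the limit of > 10000 nM in this assay, at which 2 of the 4 values shown sit.

Going by these compounds, with only one substituted chain in hand, it remains open whether the loss belongs to carboxy itself or would follow from any group at this chain carbon. A methyl ester, an amine or a hydroxy group on the same chain would separate these readings, and a longer chain ending in carboxy would test the distance from the aromatic nitrogen.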